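Swapping a phenylethyl group for an aminopropyl chain

The source may hold more compounds than are shown below. What is called first, only, known or untested is meant among the compounds shown, and "the series" means these compounds.

Of the compounds shown here, two built on one shared core have been tested so far in a functional assay on HCT-116 cells (Homo sapiens) for cytotoxicity, read by MTT assay, with a stated time of 72 h; a higher number here means a weaker inhibitor, a lower number a stronger inhibitor. Compound 1 (`CS(=O)(=O)Oc1c(C(=O)NCc2ccc(F)cc2)nc(Br)c2cccnc12`) gives > 20000 nM, which is a limit of the assay and not a number. Compound 2 (`C[C@@H](Nc1c(C(=O)NCc2ccc(F)cc2)nc(Br)c2cccnc12)c1ccccc1`) gives > 20000 nM, which is likewise only a limit. Among the measured compounds shown here, the only measured step is a step that the two limits leave unreadable from compound 1 to compound 2, so it offers no size to carry forward.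

Compound 3 (`NCCCNc1c(C(=O)NCc2ccc(F)cc2)nc(Br)c2cccnc12`) keeps the core and changes one group: 3-aminopropyl in place of 1-phenylethyl on a nitrogen on an aromatic ring. In words, 3-aminopropyl stands in place of 1-phenylethyl on a nitrogen on an aromatic ring. For the measured compounds named here, no tested compound carries this chain, so the data cannot fix the direction of the change. Going by the values given here, with the limit of > 20000 nM in this assay, at which 2 of the 2 values shown sit, as the only evidence, weak inhibition remains the expectation in this assay, and any gain in strength would be modest. The estimated change is an at least 1.6-fold lower number from compound 2 to compound 3 (0.22 log units; that floor lies within the scatter), a cautious lean toward stronger inhibition. Compound 3 is expected at about 12000 nM, with an estimated range from 3000 nM to 20000 nM.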

Compound 3, half-maximal inhibitory concentration: 18000 nM
Compound 3: middle estimate off by 1.5-fold (0.18 log units), on the low side; the measured number falls inside the stated range.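

Among the three compounds, only compound 3 gives a number and not a limit in this assay: compound 3 gives 18000 nM, so this position now has one value that can be read. The change to 3-aminopropyl gives an at least 1.1-fold lower number from compound 2 to compound 3 (0.04 log units; that floor lies within the scatter), and the change from (methylsulfonyl)oxy to (3-aminopropyl)amino gives an at least 1.1-fold lower number from compound 1 to compound 3 (0.04 log units; that floor lies within the scatter); both floors lie within the scatter, so neither establishes a gain in strength. The step from compound 1 to compound 2 cannot be read, and weak inhibition remains the picture for all three compounds, with most of the evidence still resting on one ceiling: the limit of > 20000 nM in this assay, at which 2 of the 3 values shown sit.

On these data alone, it remains open whether the amine or the chain itself accounts for the number measured for compound 3, a question that a propyl or 3-hydroxypropyl chain on the same nitrogen would help to settle. Also open, as far as these compounds go, is how the value responds to chain length, as a 2-aminoethyl or 4-aminobutyl chain would show, and whether any group here can bring the number well clear of the limit.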